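Solubility notes on a fused-ring amine series

A few compounds are considered here, and "the series" means these few. Any claim that something is new, unique, unknown or untested is made for them only; others in the source may bear on it.

Measured so far in a physicochemical assay for solubility, with a stated time of 18 h, at pH 7.4; a lower number here means a less soluble compound, a higher number a more soluble compound:
- compound 1 `COc1ccc(F)cc1CNCCCNc1ccnc2cc(CCC(C)C)ccc12` gives 4200 nM
- compound 2 `COc1ccc(F)cc1CNCCCNc1ccnc2cc(Cc3ccc(F)cc3Cl)ccc12` gives 4200 nM
- compound 3 `COc1ccc(-c2ccc3c(NCCCNCc4cc(F)ccc4OC)ccnc3c2)cc1` gives 32000 nM

Compound 3 stands highest of the three numbers; its nearest neighbour is compound 1, a step of a 7.6-fold higher number from compound 1 to compound 3 (0.88 log units; beyond the scatter), and compound 2 sits at the same distance, a 7.6-fold higher number from compound 2 to compound 3 (0.88 log units; beyond the scatter). Compound 1 and compound 2 differ from one another only as no change at the digits printed from compound 1 to compound 2 (within the scatter), which is within the scatter.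

Compound 4 `CCC(CC)c1ccc2c(NCCCNCc3cc(F)ccc3OC)ccnc2c1` is not yet measured. It differs from compound 3 as follows: pentan-3-yl in place of 4-methoxyphenyl on an aromatic carbon. The step that bears on it most directly is a 7.6-fold higher number from compound 1 to compound 3 (0.88 log units; beyond the scatter), in which the 4-methoxyphenyl replaced an isopentyl chain; compound 4 reverses that direction, putting a short branched chain back in place of the ring. A step of comparable size downward is therefore expected, a 6.4-fold lower number from compound 3 to compound 4 (0.81 log units; beyond the scatter), with the number landing near compound 1 and compound 2.

Compound 4 is expected to give 5000 nM, within 2000 nM to 14000 nM.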

Compound 4, solubility: 4200 nM
For compound 4 the middle estimate is 1.2-fold (0.08 log units) above the measured one; the measured number falls inside the stated range.
By their numbers in this assay, from the lowest: compounds 1, 2 and 4 (each within the scatter of the next); then compound 3.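

In this assay, replacing the 4-methoxyphenyl with pentan-3-yl on this aromatic carbon reverses the earlier gain (a 7.6-fold lower number from compound 3 to compound 4 (0.88 log units; beyond the scatter)), now in a direct comparison with a branched chain. The number does not separate pentan-3-yl from isopentyl (no change at the digits printed from compound 1 to compound 4 (within the scatter)) or from 2-chloro-4-fluorobenzyl (no change at the digits printed from compound 2 to compound 4 (within the scatter)), so the position tolerates these three different groups with no difference outside the scatter. Among the four compounds only compound 3 stands apart, and compound 2 goes against any reading that a ring alone raises the number, since it carries a ring and still groups with compounds 1 and 4.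

No measurement shown accounts for this separation. The compounds leave open whether the higher number of compound 3 follows the aromatic ring or its methoxy group, a question that an unsubstituted phenyl or a pyridine on this carbon would bear on.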